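Chloro to trifluoromethyl on a pyridinyl amine

The source may hold more compounds than are shown below. What is called first, only, known or untested is meant among the compounds shown, and "the series" means these compounds.

In a functional assay on CHO cells for antagonist activity at Orexin/Hypocretin receptor type 1 (Homo sapiens), read by FLIPR and calcium flux (a lower number here means a less potent compound, a higher number a more potent compound, by a factor of ten per unit of this negative logarithm), the three measured compounds stand as follows:

Compound 1 `Cc1nc(C(=O)N2CCC3(CC3)C[C@H]2CNc2ccc(Cl)cn2)c(-c2ccccc2)s1` gives 7.9.
Compound 2 `O=C(c1cc(Cl)ccc1-c1ncccn1)N1CC2(CC2)C[C@H]1CNc1ccc(C(F)(F)F)cn1` gives 8.1.
Compound 3 `Cc1ccc(-c2ncccn2)c(C(=O)N2CC3(CC3)C[C@H]2CNc2cc(C(F)(F)F)ccn2)n1` gives 6.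

Compound 1 holds the second highest of the three numbers. Its nearest neighbour is compound 2, whose value lies a little higher, within the usual scatter, so no order between the two can be claimed. Compound 3 lies far below compound 1, well beyond the scatter.

Compound 4 `Cc1nc(C(=O)N2CCC3(CC3)C[C@H]2CNc2ccc(C(F)(F)F)cn2)c(-c2ccccc2)s1` is not yet measured. It differs from compound 1 in one place: trifluoromethyl in place of chloro on an aromatic carbon. Among the compounds with values here, no measured pair shows this exact change on a shared core, so the expectation rests on the closeness of compound 1 and compound 2, where a trifluoromethyl-bearing pyridinyl amine on a different core reaches a similar value. The step from compound 1 to compound 4 in this assay is expected to be small, a number 0.10 log units higher from compound 1 to compound 4 (within the scatter), not clearly beyond the scatter in either direction. Compound 4 is therefore estimated at 8, with a range from 7.4 to 8.6.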

Compound 4, negative logarithm of the antagonist equilibrium constant: 7.7
Beside the measured number, compound 4's estimate is 0.30 log units above it; measured number inside the range.
By their numbers in this assay, from the lowest: compound 3; then compounds 4, 1 and 2 (each within the scatter of the next, the first and the last beyond it).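

In this assay, within the data shown here, this pair gives the first direct reading of trifluoromethyl in place of chloro on one shared core: the step is a number 0.20 log units lower from compound 1 to compound 4 (within the scatter) and leaves the two compounds indistinguishable. On this core, then, 5-chloropyridin-2-yl and 5-(trifluoromethyl)pyridin-2-yl cannot be told apart in this measurement, even though the entering group has 4 heavy atoms where the leaving group has 1. Nothing available here explains this closeness.

The compounds shown leave open whether a nitrile, a methoxy group or an amine on this same aromatic carbon would also stay within the scatter of compound 1. Among these compounds, they also leave open whether the same exchange would give a similarly small step on a different core, since only this one pair carries it.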